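A few compounds are considered here, and "the series" means these few. Any claim that something is new, unique, unknown or untested is made for them only; others in the source may bear on it.

Values measured so far in a functional assay on U-251 cells (Homo sapiens) for inhibition, read by sulforhodamine B assay, with a stated time of 48 h (on this read-out higher numbers stand for weaker inhibition of growth and lower numbers for stronger inhibition of growth), are these
Compound 1 `CC1(/C=C/c2ccccc2)C=CC(=O)O1` gives 89800 nM
Compound 2 `CC1(/C=C/c2ccc(C(F)(F)F)cc2)C=CC(=O)O1` gives 15700 nM

Of these two, compound 2 holds the lower number, at 15700 nM, against compound 1 at 89800 nM in the same read-out. The compound to be measured next is compound 3 `CC1(/C=C/c2ccc(F)cc2)C=CC(=O)O1` and it differs from compound 2 thus: fluoro in place of trifluoromethyl on an aromatic carbon in short, fluoro in place of trifluoromethyl on an aromatic carbon.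

Going by the values given here, only one measured step bears on this change. That is a 5.7-fold lower number from compound 1 to compound 2 (0.76 log units; beyond the scatter) for trifluoromethyl in place of hydrogen on an aromatic carbon. Among the compounds with values here, compound 3 loses that trifluoromethyl again, but no fluoro compound has been measured, so the data cannot say how much of the step would be given back. Within the data shown here, a partial return is expected in this assay with the number rising, and a rise larger than the one measured step is not expected.

The estimated step is a 2.7-fold higher number from compound 2 to compound 3 (0.43 log units; beyond the scatter) in the direction of weaker inhibition of growth.

For compound 3 the expected value is 42000 nM within an estimated range of 16000 nM to 95000 nM for repeated measurements.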

Compound 3, concentration for total growth inhibition: 60800 nM
Compound 3: middle estimate off by 1.4-fold (0.16 log units), on the low side, within the range that was stated.
By their numbers in this assay, from the lowest: compound 2; then compounds 3 and 1 (each within the scatter of the next).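

In this assay, putting fluoro in place of trifluoromethyl on this aromatic carbon gives a 3.9-fold higher number from compound 2 to compound 3 (0.59 log units; beyond the scatter) and so does not keep the stronger inhibition of growth seen with trifluoromethyl. Fluoro in place of hydrogen on the same carbon gives a 1.5-fold lower number from compound 1 to compound 3 (0.17 log units; within the scatter) and cannot be told apart from hydrogen, so among these three compounds only the trifluoromethyl of compound 2 separates from the others, and compound 1 and compound 3 form a single level. Nothing given here explains why trifluoromethyl and fluoro differ on this carbon.

The three compounds leave open whether the difference belongs to trifluoromethyl alone or would also appear with another group on this carbon, such as chloro, methoxy, nitrile, an amine or a carboxylic acid. They also leave open whether trifluoromethyl would give a similar step on another carbon of the aromatic ring, or whether the step would hold if the methyl group on the shared core gave way to a longer chain.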